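Swapping the halogenated ring on a urea nitrogen

The compounds below may be only part of what the source reports. "The series", "measured", "known", "first", "only" and "open" are said of these compounds alone.

Three compounds share a common core and were tested in an assay on isolated protein with 5-hydroxytryptamine receptor 1B (Homo sapiens) as the target; a higher number here means a larger maximal response, a lower number a smaller maximal response. Compound 1 `COc1cc2c(cc1N1CCN(C)CC1)N(C(=O)Nc1cccc(Cl)c1Cl)CC2` gives 0.6. Compound 2 `COc1cc2c(cc1N1C[C@@H](C)N[C@@H](C)C1)N(C(=O)c1ccc(-c3ccc(N4CCCC4=O)nc3C)cc1)CC2` gives 0. Compound 3 `COc1cc2c(cc1N1C[C@@H](C)N(C)[C@@H](C)C1)N(C(=O)Nc1cccc(Cl)c1Cl)CC2` gives 0.1, which is the second highest of the three numbers; it sits within the scatter of compound 2 and well apart from compound 1. Within the data shown here, the only measured step between close relatives is a number 0.50 lower from compound 1 to compound 3 (beyond the scatter), where 3,4,5-trimethylpiperazin-1-yl replaced 4-methylpiperazin-1-yl on an aromatic carbon.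

Compound 4 `COc1cc2c(cc1N1C[C@@H](C)N(C)[C@@H](C)C1)N(C(=O)Nc1cccc(C(F)(F)F)c1F)CC2` is not yet measured. It differs from compound 3 in one place: 2-fluoro-3-(trifluoromethyl)phenyl in place of 2,3-dichlorophenyl on an amide-type nitrogen. Among the measured compounds shown here, no measured pair in this set changes the ring on the amide-type nitrogen, so the one known step, which concerns the piperazine and not the urea aryl group, gives no direct guide to the size or direction of this change in this assay. With compound 3 already near the bottom of the scale and compound 2, its nearest neighbour, at zero, there is little room for a fall and no evidence for a rise. The step from compound 3 to compound 4 is therefore expected to be no change at the digits printed from compound 3 to compound 4 (within the scatter), that is, none beyond the scatter. Compound 4 is estimated to give 0.1, with a likely range from 0 to 0.3.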

Compound 4, intrinsic activity: the largest response reached, as a fraction of the reference agonist's: 0
Estimate against measurement, compound 4: 0.10 above; the measured number falls inside the stated range.
By their numbers in this assay, from the lowest: compounds 2, 4 and 3 (each within the scatter of the next); then compound 1.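

In this assay, among these compounds, putting 2-fluoro-3-(trifluoromethyl)phenyl in place of 2,3-dichlorophenyl on an amide-type nitrogen gives a number 0.10 lower from compound 3 to compound 4 (within the scatter) and is the first reading of a change at this position. With the 3,4,5-trimethylpiperazin-1-yl group held constant, the two rings cannot be told apart in this read-out, even though the entering group has 11 heavy atoms against 8 and carries fluorine where the other carries chlorine. No measurement is available that would explain this result.

Going by these compounds, both compounds in this pair carry the 3,4,5-trimethylpiperazin-1-yl group, so it remains open whether the same ring exchange would also leave the response unchanged with the 4-methylpiperazin-1-yl group of compound 1, which gives 0.6 in this assay. Also open, on these data alone, is how a phenyl ring carrying something other than halogen or trifluoromethyl, such as a nitrile, an amine or a carboxylic acid, would behave on this amide-type nitrogen.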